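Thiazolyl in place of methoxyphenyl on the ring nitrogen

The source may report more compounds than this note shows. Statements on the series, on what has been measured and on what is new or still open speak of the compounds shown alone.

Compound 1 `O/N=C(\CCN1CCN(c2nccs2)CC1)c1ccccc1`: 49.5 nM
Compound 2 `CCO/N=C(\CCN1CCN(c2ccccc2OC)CC1)c1ccccc1`: 338 nM

In a functional assay on HEK293 cells with D(4) dopamine receptor (Homo sapiens) as the target, read by FLIPR (on this read-out higher numbers stand for an effect only at larger amounts of compound and lower numbers for an effect already at smaller amounts), compound 2 gives 338 nM, the highest of the two numbers, while compound 1 gives 49.5 nM, a gap beyond the usual scatter. Compound 3 `CCO/N=C(\CCN1CCN(c2nccs2)CC1)c1ccccc1` is not yet measured. It differs from compound 2 in one place: 1,3-thiazol-2-yl in place of 2-methoxyphenyl on an amine nitrogen in a ring. Only these two measured compounds frame the question, so the expectation rests on them alone. Because compound 1, which carries the same 1,3-thiazol-2-yl group, gives 49.5 nM, the step is expected to run toward a lower number, of moderate size: a 3.1-fold lower number from compound 2 to compound 3 (0.49 log units; beyond the scatter). Compound 3 is therefore estimated at 110 nM, within 35 nM to 350 nM.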

Compound 3, half-maximal effective concentration: 81.8 nM
For compound 3 the middle estimate is 1.3-fold (0.13 log units) above the measured one, and the stated range covers the measured number.
By their numbers in this assay, from the lowest: compounds 1 and 3 (each within the scatter of the next); then compound 2.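

In this assay, the change on the ring nitrogen can now be read alone: with the ethyl on the oxygen kept, 1,3-thiazol-2-yl in place of 2-methoxyphenyl gives a 4.1-fold lower number from compound 2 to compound 3 (0.62 log units; beyond the scatter) and this lies beyond the scatter. Ethyl in place of hydrogen on the oxygen, by contrast, gives a 1.7-fold higher number from compound 1 to compound 3 (0.22 log units; within the scatter) and so makes no clear difference here. Nothing measured explains why the ring-nitrogen step occurs. As far as these compounds go, it remains open how an unsubstituted phenyl or a pyridin-2-yl on that nitrogen would read, and whether a propyl or longer chain on the oxygen would stay within the scatter.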